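The source may hold more compounds than are shown below. What is called first, only, known or untested is meant among the compounds shown, and "the series" means these compounds.

Measured in a functional assay on B16-F10 cells (Mus musculus) for antiproliferative activity, read by MTT assay, with a stated time of 48 h; a lower number here means a stronger inhibitor, a higher number a weaker inhibitor:

- Compound 1 `CCCCCCOc1ccc(C(=O)/C=C/c2c(/C=C/c3ccc(OC)cc3)cc(OC)cc2OC)cc1`: 10.4 ug/mL
- Compound 2 `COc1ccc(/C=C/c2cc(OC)cc(OC)c2/C=C/C(=O)c2ccc(-c3ccccc3)cc2)cc1`: 10.6 ug/mL

Going by the values given here, compound 2, at 10.6 ug/mL, stands level with compound 1, the only other measured compound, as their two numbers lie within the scatter of each other. The next compound to be tested is compound 3 `CCN(CC)c1ccc(C(=O)/C=C/c2c(/C=C/c3ccc(OC)cc3)cc(OC)cc2OC)cc1`, and the change is diethylamino in place of phenyl on an aromatic carbon. In words, this is diethylamino in place of phenyl on an aromatic carbon, para to a large group. Among the compounds with values here, one measured step bears on it: a 1.0-fold higher number from compound 1 to compound 2 (0.01 log units; within the scatter), with phenyl in place of hexyloxy at that same place. That step stayed within the scatter, though it is a single step and diethylamino was not part of it. No shift beyond the scatter is therefore expected in this assay, and the estimated step is a 1.1-fold lower number from compound 2 to compound 3 (0.03 log units; within the scatter). For compound 3 the expected value is 10 ug/mL, with an estimated range from 4.5 ug/mL to 21 ug/mL.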

Compound 3, half-maximal inhibitory concentration: 8.1 ug/mL
Compound 3: the middle estimate sits 1.2-fold (0.09 log units) above what was measured; low and high end bracket the measured number.
By their numbers in this assay, from the lowest: compounds 3, 1 and 2 (each within the scatter of the next).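

In this assay, diethylamino on this aromatic carbon, para to a large group, gives a 1.3-fold lower number from compound 2 to compound 3 (0.12 log units; within the scatter) when it replaces phenyl, and a 1.3-fold lower number from compound 1 to compound 3 (0.11 log units; within the scatter) when it replaces hexyloxy. Going by these compounds alone, the position therefore now carries an amine as well as the earlier ether and aromatic ring, and across these three different groups in compounds 1, 2 and 3, no step leaves the scatter. No other measurement accompanies these results to speak to them.

From the compounds shown here alone, whether a carboxylic acid, a primary amine or a fluorine at this position would produce a step beyond the scatter remains open. Going by these compounds, it is also open whether changes elsewhere on the shared core, such as replacing the methoxy groups with hydroxyl groups, would leave the numbers equally unchanged.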